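Carboxyphenoxy in place of styryl on a shared core

A few compounds are considered here, and "the series" means these few. Any claim that something is new, unique, unknown or untested is made for them only; others in the source may bear on it.

Measured so far:
compound 1, `COc1ccccc1-c1ccc([C@H]2S[C@@H](C)C(=O)Nc3c2c(C)nn3-c2ccccc2C)cc1`: 1100 nM
compound 2, `Cc1ccccc1-n1nc(C)c2c1NC(=O)[C@H](C)S[C@@H]2c1ccc(/C=C/c2ccccc2)cc1`: "not active" (no number reported)

In an assay on isolated protein for agonist activity at Bile acid receptor (Homo sapiens), read by AlphaScreen, with a stated time of 30 min (on this read-out lower numbers stand for an effect already at smaller amounts and higher numbers for an effect only at larger amounts of compound), compound 1 gives 1100 nM. Among the compounds with values here, compound 2 carries a 2-phenylethenyl group where compound 1 carries a methoxyphenyl group, and in this assay compound 2 is reported as "not active" (no number reported), so no single number stands for it and no step can be computed from it.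

Compound 3, `Cc1ccccc1-n1nc(C)c2c1NC(=O)[C@H](C)S[C@@H]2c1ccc(Oc2ccc(C(=O)O)cc2)cc1`, has not been measured yet. It differs from compound 2 in one place: 4-carboxyphenoxy in place of 2-phenylethenyl on an aromatic carbon.

Within the data shown here, no step between measured compounds is known, so the size of the change from compound 2 to compound 3 in this assay cannot be computed. Since compound 2 gives no number, any value at all for compound 3 would be a gain; a measurable number, near what compound 1 shows, is what is expected, though a repeat of "not active" cannot be ruled out.

Compound 3 is estimated at 2000 nM, with a range from 300 nM to 20000 nM.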

Compound 3, half-maximal effective concentration: "not active" (no number reported)
Compound 3: no number reported; no gap can be computed for the estimate.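

Within the data shown here, compound 2 and compound 3 are both reported as "not active" in this assay, and no step between them can be read. Nothing shown bears on why this is. The compounds shown leave open whether 2-phenylethenyl and 4-carboxyphenoxy differ at all in this test.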